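The source may hold more compounds than are shown below. What is called first, only, known or untested is meant among the compounds shown, and "the series" means these compounds.

The measured compounds:
Compound 1, `CNc1nc(N2CC(N(C)C)C2)nc2ccc(Cl)cc12`: in an assay on HEK293 cells for displacement of a labelled ligand from 5-hydroxytryptamine receptor 3A (Homo sapiens), read by scintillation counting, with a stated time of 24 h, in the presence of a further agent that is not named here (on this read-out higher numbers stand for weaker inhibition and lower numbers for stronger inhibition), compound 1 gives 468 nM.
Compound 2, `CN1CCN(c2nc(NCc3ccc(N)cc3)c3cc(Cl)ccc3n2)CC1`: in this assay compound 2 gives 2.69 nM.
Compound 3, `CN1CCN(c2cc3ccccc3c(N)n2)CC1`: in this assay compound 3 gives 219 nM.

Compound 3 stands second highest of these three numbers. Its nearest neighbour is compound 1, whose number is higher by an amount beyond the scatter; the furthest is compound 2, whose number is much lower, again beyond the scatter. Within the data shown here, no two of the measured compounds differ in one place only, so no single step has been measured among them.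

Compound 4, `CN1CCN(c2cc3ccccc3cn2)CC1`, differs from compound 3 in one place: hydrogen in place of amino on an aromatic carbon. The measured compounds give no direct reading of this change. The step of a 3.0-fold higher number from compound 3 to compound 4 (0.47 log units; beyond the scatter) is expected to raise the number, towards weaker inhibition, by an amount somewhat beyond the scatter. Compound 4 is therefore estimated at 650 nM, with a range from 150 nM to 2800 nM.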

Compound 4, inhibition constant: 1.62 nM
Beside the measured number, compound 4's estimate is 400-fold (2.60 log units) above it; measured number below the stated range.
By their numbers in this assay, from the lowest: compounds 4 and 2 (each within the scatter of the next); then compound 3; then compound 1.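

In this assay hydrogen in place of amino on the aromatic carbon next to the ring nitrogen gives a 140-fold lower number from compound 3 to compound 4 (2.13 log units; beyond the scatter) and thus a large move towards stronger inhibition. This first measured single step shows that the amino group is not needed at this position for strong inhibition, and that this one change can shift the number by far more than the scatter. Nothing shown here explains why the change has so large an effect.

The compounds shown leave open whether the higher number belongs to amino in particular or would also appear with a methyl group, a methoxy group or a chlorine atom on this carbon. They also leave open whether the same step would hold on another core, such as that of compound 2.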